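The source may report more compounds than this note shows. Statements on the series, on what has been measured and on what is new or still open speak of the compounds shown alone.

Measured so far in a functional assay on Jurkat cells (Homo sapiens) for inhibition, read by CCK-8 assay, with a stated time of 48 h; a higher number here means a weaker inhibitor of growth, a lower number a stronger inhibitor of growth:
- compound 1 `Cc1ccc(CNc2nc(Nc3ccc(N4CCN(C)CC4)cn3)ncc2Cl)cc1` gives 12700 nM
- compound 2 `Cc1cccc(Nc2nc(Nc3ccc(N4CCN(C)CC4)cn3)ncc2Cl)c1` gives 15300 nM

With only these two numbers available, compound 2 holds the higher one, but it cannot be separated from compound 1 . The step between them is a 1.2-fold higher number from compound 1 to compound 2 (0.08 log units; within the scatter), and it replaces 4-methylbenzyl with 3-methylphenyl on a nitrogen on an aromatic ring.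

The next compound changes that same place. Compound 3 `CCc1ccc(Nc2nc(Nc3ccc(N4CCN(C)CC4)cn3)ncc2Cl)cc1` carries 4-ethylphenyl in place of 3-methylphenyl on a nitrogen on an aromatic ring, a difference that counts as 4-ethylphenyl in place of 3-methylphenyl on a nitrogen on an aromatic ring.

Among the measured compounds shown here, no measured step covers this exact exchange, so the one step at this place is the only guide, and it is thin evidence. That step stayed within the scatter, so no shift beyond the scatter is expected in this assay, and no direction can be argued with any confidence. The estimated step is a 1.2-fold lower number from compound 2 to compound 3 (0.07 log units; within the scatter), which is expected to be indistinguishable from no change.

For compound 3 the estimated value is 13000 nM, with an expected range from 5500 nM to 30000 nM.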

Compound 3, concentration for 50% growth inhibition: 11100 nM
Beside the measured number, compound 3's estimate is 1.2-fold (0.07 log units) above it; the range from low to high includes it.
By their numbers in this assay, from the lowest: compounds 3, 1 and 2 (each within the scatter of the next).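

In this assay, this place on a nitrogen on an aromatic ring has now taken a third group without any separable effect: 4-ethylphenyl in place of 3-methylphenyl gives a 1.4-fold lower number from compound 2 to compound 3 (0.14 log units; within the scatter), and 4-ethylphenyl in place of 4-methylbenzyl gives a 1.1-fold lower number from compound 1 to compound 3 (0.06 log units; within the scatter). Among the compounds shown here, the single earlier step therefore does not stand alone, since compound 1, compound 2 and compound 3 cannot be told apart, with compound 3 at 11100 nM, even though the exchanges alter the alkyl group on the phenyl ring and the link to it. No independent measurement bears on why these three groups read alike.

The compounds shown leave open whether this place responds at all to a group of a different kind, such as an amine, a carboxylic acid or a hydroxyl on the phenyl ring, since the groups seen so far carry only carbon and hydrogen. They also leave open whether a change elsewhere on the shared core, which is identical in all three compounds, would produce a step beyond the scatter.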